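The source may report more compounds than this note shows. Statements on the series, on what has been measured and on what is new or still open speak of the compounds shown alone.

Values in an ADME assay on MT4 cells (Homo sapiens) for cytotoxicity, read by MTT assay; on this read-out higher numbers stand for lower toxicity in this test and lower numbers for higher toxicity in this test:
- compound 1 `Cc1ccc(N(C(=O)c2ccccc2[N+](=O)[O-])C(=S)OCCN2C(=O)c3ccccc3C2=O)cc1`: 100000 nM
- compound 2 `O=C1c2ccccc2C(=O)N1CCOC(=S)N(C(=O)c1cccc(Cl)c1Cl)c1ccc(Cl)cc1`: 54000 nM
- compound 3 `O=C1c2ccccc2C(=O)N1CCOC(=S)N(C(=O)c1cc([N+](=O)[O-])ccc1Cl)c1ccc(Cl)cc1`: 45000 nM

In this assay the values of compound 1 and compound 3 each lie within the scatter of compound 2, so compound 2 has no clear rank among the three.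

Compound 4 `Cc1ccc(N(C(=O)c2cccc(Cl)c2Cl)C(=S)OCCN2C(=O)c3ccccc3C2=O)cc1` is the next case. It keeps the 2,3-dichlorophenyl on the carbonyl carbon of compound 2 and changes the other aromatic ring: methyl in place of chloro on an aromatic carbon. In words, this is methyl in place of chloro on an aromatic carbon, 4-chlorophenyl to 4-methylphenyl.

Within the data shown here, the only measured step, a 1.2-fold lower number from compound 2 to compound 3 (0.08 log units; within the scatter), lies at the carbonyl side, not at the place that changes here, so it bears only indirectly. It does show that one change on this core can leave the number within the scatter. Compound 1 already carries the 4-methylphenyl but also differs on the carbonyl side, so no measurement isolates the new change. Its value of 100000 nM still gives no sign of higher toxicity in this set.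

No shift beyond the scatter is therefore expected, and the expected change is a 1.1-fold higher number from compound 2 to compound 4 (0.05 log units; within the scatter). For compound 4 the estimated value is 60000 nM, with an expected range of 30000 nM to 100000 nM.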

Compound 4, half-maximal cytotoxic concentration: 35000 nM
Beside the measured number, compound 4's estimate is 1.7-fold (0.23 log units) above it; low and high end bracket the measured number.
By their numbers in this assay, from the lowest: compounds 4, 3, 2 and 1 (each within the scatter of the next, the first and the last beyond it).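

In this assay, the exchange of 4-chlorophenyl for 4-methylphenyl, with the 2,3-dichlorophenyl on the carbonyl carbon held fixed, now has its own reading: a 1.5-fold lower number from compound 2 to compound 4 (0.19 log units; within the scatter). This gives the first isolated measure at this aromatic carbon, and on this core the methyl in place of chloro leaves the number within the scatter. Among these compounds, with the 4-methylphenyl held fixed, the carbonyl side gives a 2.9-fold lower number from compound 1 to compound 4 (0.46 log units; beyond the scatter), the only modest step in the set that lies beyond the scatter, so the one clear difference seen so far belongs to 2,3-dichlorophenyl in place of 2-nitrophenyl and not to the exchange of chloro for methyl; no measurement at hand accounts for that step.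

The compounds shown leave open whether an amine or a carboxylic acid in place of the chloro of compound 2 would also stay within the scatter of compound 2. They also leave open whether the carbonyl-side step seen with the 4-methylphenyl would carry over to a core bearing the 4-chlorophenyl, since no pair shown tests that exchange there.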